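Trimming the propyl chain of compound 3

This account rests on a few compounds, and the source may have more. Where it says the series, first, only, none or still open, it means among the compounds named here.

compound 1 `COc1ccc(Nc2nc(NC3CCCC3)c3ccccc3n2)cc1`: 12600 nM
compound 2 `COc1ccc(Nc2nc(NCCCO)c3ccccc3n2)cc1`: 17100 nM
compound 3 `CCCNc1nc(Nc2ccc(OC)cc2)nc2ccccc12`: 5090 nM

These three compounds share one core and differ only in the group on one nitrogen. In a functional assay on KBVIN cells (Homo sapiens) for antiproliferative activity, read by sulforhodamine B assay, with a stated time of 48 h (a higher number here means a weaker inhibitor of growth, a lower number a stronger inhibitor of growth), compound 3 has the lowest number of the three, which makes it the strongest inhibitor of growth so far. Two measured steps lead to it, a 2.5-fold lower number from compound 1 to compound 3 (0.39 log units; beyond the scatter) and a 3.4-fold lower number from compound 2 to compound 3 (0.53 log units; beyond the scatter), and both are modest. The remaining step, a 1.4-fold higher number from compound 1 to compound 2 (0.13 log units; within the scatter), does not separate the other two compounds.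

The next compound is compound 4 `CNc1nc(Nc2ccc(OC)cc2)nc2ccccc12`. The change is hydrogen in place of ethyl on a saturated chain carbon bound to a nitrogen on an aromatic ring, so propylamino becomes methylamino.

Among the compounds with values here, no measured step shortens a chain, so the data do not test this change directly. Within the data shown here, the only guide is that both other groups give higher numbers than the propyl of compound 3. A modest rise in this assay therefore seems more likely than a fall, though a change within the scatter remains possible. The expected step is a 1.6-fold higher number from compound 3 to compound 4 (0.20 log units; within the scatter). The estimated value for compound 4 is 8000 nM, with an expected range from 3500 nM to 20000 nM.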

Compound 4, concentration for 50% growth inhibition: 17500 nM
Beside the measured number, compound 4's estimate is 2.2-fold (0.34 log units) below it; the range from low to high includes it.
By their numbers in this assay, from the lowest: compound 3; then compounds 1, 2 and 4 (each within the scatter of the next).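

In this assay, within the data shown here, cutting the propyl chain of compound 3 down to methyl weakens growth inhibition, with a 3.4-fold higher number from compound 3 to compound 4 (0.54 log units; beyond the scatter) as the first measured step that shortens a chain, so the ethyl that leaves does count at this position. Compound 4 also cannot be told apart from the other two compounds, with a 1.0-fold higher number from compound 2 to compound 4 (0.01 log units; within the scatter) and a 1.4-fold higher number from compound 1 to compound 4 (0.14 log units; within the scatter), which leaves methyl, 3-hydroxypropyl and cyclopentyl level with one another and propyl alone standing apart among these four groups. No measurement shown here explains why the propyl group stands apart.

The compounds shown leave open whether the number keeps falling as the chain grows past propyl, which a butyl or pentyl chain on this nitrogen would test, and where an ethyl group would fall between methyl and propyl. They also leave open whether a methoxy group or an amine at the end of the propyl chain would match the result for the hydroxy group of compound 2 or stay closer to compound 3.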